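From compound 3 to compound 4: losing the diethylamino end

This account rests on a few compounds, and the source may have more. Where it says the series, first, only, none or still open, it means among the compounds named here.

Values in a functional assay on MCF7 cells (Homo sapiens), read by MTT assay, with a stated time of 48 h; on this read-out higher numbers stand for weaker inhibition and lower numbers for stronger inhibition
- Compound 1 `CCN(CC)CCNC(=O)c1ccc(C(CC)(CC)c2ccc(OCC(O)C(C)(C)C)c(C)c2)n1CC` gives 690 nM
- Compound 2 `CCn1c(C(=O)NCCCN(C)C)ccc1C(CC)(CC)c1ccc(OCC(O)C(C)(C)C)c(C)c1` gives 490 nM
- Compound 3 `CCN(CC)CCCNC(=O)c1ccc(C(CC)(CC)c2ccc(OCC(O)C(C)(C)C)c(C)c2)n1CC` gives 190 nM

Compound 3 stands lowest of the three, reached by modest steps beyond the scatter (a 3.6-fold lower number from compound 1 to compound 3 (0.56 log units; beyond the scatter) and a 2.6-fold lower number from compound 2 to compound 3 (0.41 log units; beyond the scatter)). The remaining step stays within the scatter (a 1.4-fold lower number from compound 1 to compound 2 (0.15 log units; within the scatter)). Compound 4 `C#CCNC(=O)c1ccc(C(CC)(CC)c2ccc(OCC(O)C(C)(C)C)c(C)c2)n1CC` alters the same chain (ethynyl in place of 2-(diethylamino)ethyl on a saturated chain carbon bound to an amide-type nitrogen), with ethynyl in place of 2-(diethylamino)ethyl on a saturated chain carbon bound to an amide-type nitrogen. Compound 1, compound 2 and compound 3 all keep a diethylamino or dimethylamino end, which compound 4 lacks, so these steps are only a loose guide. A rise somewhat larger than those modest steps is expected (a 6.3-fold higher number from compound 3 to compound 4 (0.80 log units; beyond the scatter)). For compound 4 the estimated value is 1200 nM, with an expected range of 300 nM to 6000 nM.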

Compound 4, half-maximal inhibitory concentration: > 50000 nM
Compound 4: only a limit was reported (the forecaster's own chance of this, stated with the estimate: 10%); middle value at least 41-fold (1.61 log units) away from the limit.
By their numbers in this assay, from the lowest: compound 3; then compounds 2 and 1 (each within the scatter of the next). At a limit, above all of these: compound 4.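

In this assay, compound 4 gives only a limit of the assay, > 50000 nM, not a number. Among the amine-ended chains, changes at this place moved the number modestly at most, but swapping the whole end for propargyl is a far larger step: an at least 260-fold higher number from compound 3 to compound 4 (2.42 log units; beyond the scatter), an at least 100-fold higher number from compound 2 to compound 4 (2.00 log units; beyond the scatter) and an at least 72-fold higher number from compound 1 to compound 4 (1.86 log units; beyond the scatter). So the chain on the amide-type nitrogen is not freely replaceable, and an end without an amine can cost nearly all measurable effect.

Compound 4 both loses the amine and shortens the chain, and these two changes cannot be told apart here. A plain hexyl chain, or a propargyl chain ending in a diethylamino group, would separate them.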